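Nitrile-Bearing Side Chain in Place of Methoxyphenoxy

A few compounds are considered here, and "the series" means these few. Any claim that something is new, unique, unknown or untested is made for them only; others in the source may bear on it.

Compound 1 `N#Cc1ccc(C2OCC(C/C=C\CCC(=O)O)C(c3cccnc3)O2)cc1`: in an assay for inhibition of Thromboxane-A synthase (Homo sapiens), using microsomes (a lower number here means a stronger inhibitor, a higher number a weaker inhibitor), compound 1 gives 24 nM.
Compound 2 `COc1ccc(OC(C)(C)C2OCC(C/C=C\CCC(=O)O)C(c3cccnc3)O2)cc1`: in this assay compound 2 gives 41 nM.

Compound 2 has the higher of these two numbers, but its gap to compound 1 lies within the scatter, so the two cannot be ranked. Compound 3 `CC(C)(Cc1ccc(F)cc1C#N)C1OCC(C/C=C\CCC(=O)O)C(c2cccnc2)O1` differs from compound 2 in one place: a group of 10 heavy atoms (8 carbon, 1 nitrogen, 1 fluorine; one six-membered aromatic ring of carbon only) in place of a group of 9 heavy atoms (7 carbon, 2 oxygen; one six-membered aromatic ring of carbon only), on a saturated chain carbon bound to two saturated chain carbons and a saturated ring carbon. Going by the values given here, no measured pair shows a change of this kind, so the step is uncertain. A shift toward a lower number, or none beyond the scatter, seems most likely in this assay because compound 1 gives 24 nM while also carrying a nitrile. Compound 3 is therefore expected near 25 nM, within 8 nM to 80 nM. That means an expected step of a 1.6-fold lower number from compound 2 to compound 3 (0.21 log units; within the scatter).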

Compound 3, half-maximal inhibitory concentration: < 10 nM
Compound 3 was reported as a limit; the forecaster's own chance of this, stated with the estimate: 3%; middle value at least 2.5-fold (0.39 log units) from the limit.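

At the saturated chain carbon bound to two saturated chain carbons and a saturated ring carbon, exchanging 4-methoxyphenoxy for the ring group bearing fluorine and nitrile gives an at least 4.1-fold lower number from compound 2 to compound 3 (0.61 log units; beyond the scatter) in this assay, so this position does respond to a change of group. Compound 3 is reported only as a limit, < 10 nM. The full size of the step therefore cannot be read: the limit of < 10 nM in this assay, at which 1 of the 3 values shown sits.

The compounds shown leave open whether the nitrile or the fluorine alone would give this step. From the compounds shown here alone, how an amine or a longer chain would read at this carbon also remains unknown.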